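Series notes: oxazolidinone in place of the aminomethyl pyrazole

A few compounds are considered here, and "the series" means these few. Any claim that something is new, unique, unknown or untested is made for them only; others in the source may bear on it.

Compound 2 `Cc1nn(CC(=O)N2CCN(c3sc(C(F)(F)F)nc3-c3nc4ccccc4[nH]3)C[C@H]2C)cc1CN(C)C` holds the lowest number of the two measured: in a functional assay on CHO-K1 cells for antagonist activity at C-X-C chemokine receptor type 3 (Homo sapiens), read by FLIPR, with a stated time of 10 min, in the presence of a further agent that is not named here (a lower number here means a stronger inhibitor, a higher number a weaker inhibitor), compound 2 gives 2.7 nM, while compound 1 `C[C@@H]1CN(c2sc(C(F)(F)F)nc2-c2nc3ccccc3[nH]2)CCN1C(=O)Cn1ccc(C(=O)O)n1` gives 2100 nM. Compound 3 `C[C@@H]1CN(c2sc(C(F)(F)F)nc2-c2nc3ccccc3[nH]2)CCN1C(=O)CN1C(=O)OC[C@@H]1c1ccccc1` carries 2-oxo-4-phenyl-1,3-oxazolidin-3-yl in place of 4-((dimethylamino)methyl)-3-methyl-1H-pyrazol-1-yl on a saturated chain carbon bound to a carbonyl carbon. Among the measured compounds shown here, the one measured step at this position, a 780-fold lower number from compound 1 to compound 2 (2.89 log units; beyond the scatter), shows that the group leaving in compound 3 set the number of compound 2; no step covers the entering group. A weaker number is therefore expected for compound 3, with wide uncertainty, as a 110-fold higher number from compound 2 to compound 3 (2.05 log units; beyond the scatter). Compound 3 is estimated at 300 nM, within 30 nM to 3000 nM.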

Compound 3, half-maximal inhibitory concentration: 360 nM
Compound 3: middle estimate off by 1.2-fold (0.08 log units), on the low side; the range from low to high includes it.
By their numbers in this assay, from the lowest: compound 2; then compound 3; then compound 1.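

In this assay the swap to 2-oxo-4-phenyl-1,3-oxazolidin-3-yl gives a 130-fold higher number from compound 2 to compound 3 (2.12 log units; beyond the scatter) at this place, so this ring does not replace the aminomethyl pyrazole on equal terms. The same group still gives a 5.8-fold lower number from compound 1 to compound 3 (0.77 log units; beyond the scatter) against 3-carboxy-1H-pyrazol-1-yl, which places it in the middle of the three. No measured evidence bears on the reason for this order.

Open, as far as these compounds go, is whether the dimethylamino group alone sets the low number of compound 2, as a dimethylaminomethyl group on a phenyl ring would test. Also open, from the compounds shown here alone, is what the phenyl group and its stereocentre contribute to the oxazolidinone.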